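(1-Bromoethyl)carbonyl Enters on a Ring Nitrogen

This account rests on a few compounds, and the source may have more. Where it says the series, first, only, none or still open, it means among the compounds named here.

Measured compounds:
compound 1, `COc1ccc(C2=NNC(c3ccco3)C2)cc1OC`, 45%
compound 2, `COc1ccc(C2CC(c3ccc(OC)c(OC)c3)=NN2C(=O)CBr)c(OC)c1`, 53%
compound 3, `COc1ccc(C2=NN(C(=O)CO[N+](=O)[O-])C(c3c(Cl)cccc3Cl)C2)cc1`, 34%

All three were tested in a functional assay on the whole organism (strain albino) for inhibition, with Rattus norvegicus as the target, read by paw edema, with stated times of 30 min and 1 h, at a dose of 100 mg/kg by the oral route; on this read-out higher numbers stand for more inhibition at the one dose given (going by the name of the read-out) and lower numbers for less inhibition. Compound 1 gives 45%, the second highest of the three numbers. Its nearest neighbour is compound 2, whose value of 53% lies within the usual scatter of compound 1; the furthest is compound 3, whose value of 34% is beyond the scatter, lower than compound 1. Among the measured compounds shown here, compounds 2 and 3 differ from compound 1 in more than one place, so no single step between measured compounds is available.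

Compound 4, `COc1ccc(C2=NN(C(=O)C(C)Br)C(c3ccco3)C2)cc1OC`, is not yet measured. It differs from compound 1 by (1-bromoethyl)carbonyl in place of hydrogen on an amine nitrogen in a ring. Compound 2 also carries a carbonyl group bearing a bromine on the same kind of ring nitrogen, and compound 2 gives 53%, a number within the scatter of compound 1. On that basis compound 4 is expected to show a step of a number 5 percentage points higher from compound 1 to compound 4 (within the scatter), upward but not beyond the scatter. Compound 4 is estimated to give 50%, expected to fall between 36% and 64%.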

Compound 4, a percentage reported as inhibition, in the whole organism at one dose (the size of the read-out at that dose, not a potency): 22%
Compound 4: the middle estimate sits 28 percentage points above what was measured, and the stated range ends above it.
By their numbers in this assay, from the lowest: compound 4; then compound 3; then compounds 1 and 2 (each within the scatter of the next).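

In this assay, putting (1-bromoethyl)carbonyl in place of hydrogen on an amine nitrogen in a ring gives a number 23 percentage points lower from compound 1 to compound 4 (beyond the scatter). Among the compounds shown here, this is the first comparison in which only that nitrogen changes, so it shows directly that this position is sensitive to what it carries: here, the read-out drops when this group replaces the hydrogen. The earlier compounds could not show this, as each differs from compound 1 in more than one place, and nothing available explains the drop.

Only one replacement at this nitrogen on this core is shown, so it remains open whether the loss comes with any carbonyl group there or depends on the bromine and the rest of this particular group. A plain acetyl group, a bromine-free propanoyl group or a longer chain ending in an amine at the same nitrogen would help separate these possibilities, and each result would show whether any group on this nitrogen can keep the level of the parent compound.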